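This account rests on a few compounds, and the source may have more. Where it says the series, first, only, none or still open, it means among the compounds named here.

Compound 1 `CC(C)[C@H]1CC[C@@]2(CO2)[C@H]2C(=O)OCC(C(=O)OCc3ccc(-c4ccc([N+](=O)[O-])cc4)o3)=C[C@H]12` and compound 2 `CC(C)[C@H]1CC[C@@](O)(CO)[C@H]2C(=O)OCC(C(=O)O)=C[C@H]12` share a core but differ from each other in more than one place, so only their two values can be set side by side. In a functional assay on HCT-116 cells (Homo sapiens) for inhibition, with a stated time of 72 h (on this read-out lower numbers stand for stronger inhibition and higher numbers for weaker inhibition), compound 1 gives 620 nM. Compound 2 reaches no number in this assay but only a limit, > 32000 nM. Compound 2 thus stands at the weak end of what has been measured, sitting at the limit of > 32000 nM in this assay, at which 1 of the 2 values shown sits. Compound 3 `CC(C)[C@H]1CC[C@@](O)(CCl)[C@H]2C(=O)OCC(C(=O)O)=C[C@H]12` has not yet been measured. It differs from compound 2 in a single place: chloro in place of hydroxy on a saturated chain carbon bound to a saturated ring carbon. Going by the values given here, no step between measured compounds is available, so the size of the move in this assay cannot be read from any earlier pair. The change is a small one and leaves the free carboxylic acid of compound 2 in place, so no step beyond the usual scatter is expected. Compound 3 is therefore estimated at about 40000 nM, within a range from 8000 nM to 150000 nM, and most likely only a limit will again be reported. That estimate corresponds to a step that the limit leaves unreadable from compound 2 to compound 3.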

Compound 3, half-maximal inhibitory concentration: 220 nM
Estimate against measurement, compound 3: 180-fold (2.26 log units) above; measured number below the stated range.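

In this assay, chloro in place of hydroxy on a saturated chain carbon bound to a saturated ring carbon gives an at least 140-fold lower number from compound 2 to compound 3 (2.16 log units; beyond the scatter), so exchanging one heavy atom at this place is enough for a large step. The earlier compounds shown here could not show this: compound 1 and compound 2 differ in more than one place, and no single change could be read from them. The free carboxylic acid also remains in compound 3, which gives 220 nM, so in this pair the acid does not by itself prevent a clear effect on these cells. The full size of the step stays unknown because compound 2 has only a limit: the limit of > 32000 nM in this assay, at which 1 of the 3 values shown sits.

The pair cannot separate what chloro brings from what is lost with hydroxy, and a plain methyl at the same place would help to tell these two apart. From the compounds shown here alone, it also remains open whether bromo, fluoro or an amine at this place would move the number as far, and whether the hydroxymethyl to chloromethyl change would have the same effect on a different part of the molecule, such as an ester in place of the carboxylic acid.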